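The compounds below may be only part of what the source reports. "The series", "measured", "known", "first", "only" and "open" are said of these compounds alone.

Of the compounds shown here, three have so far been tested in a functional assay on CHO-K1 cells for agonist activity at Glucose-dependent insulinotropic receptor (Homo sapiens), read by a luciferase reporter, with a stated time of 5 h; a higher number here means that more compound is needed for the effect, a lower number that less compound is needed. Compound 1 `CC(C)(C)OC(=O)N1CCC(Oc2cccc3c2ccn3-c2ccc(S(C)(=O)=O)cc2)CC1` gives 631 nM. Compound 2 `CC(C)OC(=O)N1CCC(Oc2ncnc3c2CCN3c2ccc(S(C)(=O)=O)cc2)CC1` gives 126 nM, the lowest of the two numbers; compound 1 stands well above it, by more than the usual scatter of repeated runs. For compound 3 `CC(C)OC(=O)N1CCC(Oc2ncnc3c2CC(C)N3c2ccc(S(C)(=O)=O)cc2F)CC1` the result is only a limit of the assay, > 10000 nM; > 10000 nM (2 entries), so no number can be placed against it.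

Compound 4 `CC(C)OC(=O)N1CCC(Oc2ncnc3c2CCN3c2ccc(C#N)cn2)CC1` has not yet been measured. It differs from compound 2 in a single place: 5-cyanopyridin-2-yl in place of 4-(methylsulfonyl)phenyl on a nitrogen on an aromatic ring in a ring. For the measured compounds named here, no pair of measured compounds differs by this same exchange, so there is no measured step to lean on; only the gap between compound 1 and compound 2 shows how far changes elsewhere can move the read-out. A swap of one aromatic substituent for another of similar size is expected to shift the number only moderately, and the step from compound 2 to compound 4 is estimated at about a 2.0-fold higher number from compound 2 to compound 4 (0.30 log units; within the scatter), toward a higher number but with a wide uncertainty. Compound 4 is therefore expected to give roughly 250 nM, within a range from 60 nM to 1200 nM.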

Compound 4, half-maximal effective concentration: 794 nM
Compound 4: the middle estimate sits 3.2-fold (0.50 log units) below what was measured; measured number inside the range.
By their numbers in this assay, from the lowest: compound 2; then compounds 1 and 4 (each within the scatter of the next).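

In this assay, for the compounds shown here, the exchange of 4-(methylsulfonyl)phenyl for 5-cyanopyridin-2-yl on the ring nitrogen gives a 6.3-fold higher number from compound 2 to compound 4 (0.80 log units; beyond the scatter), the first measured step at this place, and it shows that the read-out depends on which aromatic group sits there. The two groups are counted alike for hydrogen-bond donors and acceptors and neither carries a net charge, so these simple counts do not separate them, even though the result differs by more than the usual scatter. Nothing measured here explains why more compound is needed after this exchange.

This single step changes two things at once, the ring, from carbon only to one holding a nitrogen, and the substituent, from methylsulfonyl to nitrile, so the compounds shown leave open which of the two matters; a phenyl ring carrying a nitrile, or a pyridine ring carrying methylsulfonyl, would pull them apart. Also open, from the compounds shown here alone, is how other substituents on this ring, such as an amide or a small amine, would read out with the same core.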